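Amide ring variation on the shared sulfonylpiperazine core

This account rests on a few compounds, and the source may have more. Where it says the series, first, only, none or still open, it means among the compounds named here.

Measured so far:
- compound 1 `C[C@@H](C(=O)N1CC2CC2C1)N1CCN(S(=O)(=O)c2ccc(C(C)(C)C)cc2)CC1`; in an ADME assay on HepG2 cells (Homo sapiens) for inhibition, with a stated time of 48 h (on this read-out higher numbers stand for an effect only at larger amounts of compound and lower numbers for an effect already at smaller amounts), compound 1 gives > 40000 nM, which is a limit of the assay.
- compound 2 `C[C@@H](C(=O)N1CCCCC1)N1CCN(S(=O)(=O)c2ccc(C(C)(C)C)cc2)CC1`; in this assay compound 2 gives > 40000 nM, again a limit of the assay and not a number.

Going by the values given here, compound 2 therefore stands at the limit of this assay, and the one further value shown sits at the same limit (the limit of > 40000 nM in this assay, at which 2 of the 2 values shown sit). As far as these compounds go, the step that the two limits leave unreadable from compound 1 to compound 2 cannot be read because both of its ends are limits (the limit of > 40000 nM in this assay, at which 2 of the 2 values shown sit), so its size and direction remain unknown.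

Compound 3 `C[C@@H](C(=O)N1CCC(F)(F)CC1)N1CCN(S(=O)(=O)c2ccc(C(C)(C)C)cc2)CC1` is not yet measured. It differs from compound 2 by 4,4-difluoropiperidin-1-yl in place of piperidin-1-yl on a carbonyl carbon. Among the compounds with values here, no measured step in this assay is readable, so none bears on this change with a size; the only information is that both measured compounds sit at the limit (the limit of > 40000 nM in this assay, at which 2 of the 2 values shown sit). On that basis, compound 3 is expected to show no effect within the measured range as well.

The step that the limit leaves unreadable from compound 2 to compound 3 is therefore expected to lie within the scatter, with the result again most likely a limit. Compound 3 is estimated at 60000 nM, with a range from 20000 nM to 200000 nM.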

Compound 3, half-maximal effective concentration: > 40000 nM
Compound 3 gave a limit, no number; the forecaster's own chance of this, stated with the estimate: 85%; the middle value does not contradict the limit.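

Compound 3 also ends at a limit in this assay, so no step among compound 1, compound 2 and compound 3 can be read, in size or in direction: the limit of > 40000 nM in this assay, at which 3 of the 3 values shown sit.

The compounds shown leave open whether any amide ring on the shared core gives a measurable effect in this assay.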